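A Triazole Tail in Place of Benzyl

A few compounds are considered here, and "the series" means these few. Any claim that something is new, unique, unknown or untested is made for them only; others in the source may bear on it.

Measured so far:
compound 1 `CCCCNc1nc(N)nc(C)c1CCCN1CCCC1` gives 110 nM in an assay on HEK293 cells for agonist activity at Toll-like receptor 8 (Homo sapiens), read by spectrophotometry; a lower number here means that less compound is needed, a higher number that more compound is needed for the effect
compound 2 `CCCCNc1nc(N)nc(C)c1CCCCc1ccccc1` gives 857 nM in this assay

Compound 2 stands at the higher of the two numbers; its nearest neighbour is compound 1, and the step of a 7.8-fold higher number from compound 1 to compound 2 (0.89 log units; beyond the scatter) separates them. Compound 3 `CCCCNc1nc(N)nc(C)c1CCCn1cncn1` has not yet been measured. It differs from compound 2 as follows: 1H-1,2,4-triazol-1-yl in place of benzyl on a saturated chain carbon, three bonds along the chain from an aromatic carbon. Among the compounds with values here, only one measured step bears on this change, the exchange of the saturated ring for the benzyl group in a 7.8-fold higher number from compound 1 to compound 2 (0.89 log units; beyond the scatter), which raised the number well beyond the scatter. Within the data shown here, the triazolyl group of compound 3 is neither the saturated ring of compound 1 nor the carbocyclic ring of compound 2, so the single step gives only a rough guide. Compound 3 is expected to land between its two neighbours, with a step of a 2.1-fold lower number from compound 2 to compound 3 (0.33 log units; beyond the scatter) that is likely modest and downward. The estimate for compound 3 in this assay is 400 nM, within a range of 120 nM to 1500 nM.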

Compound 3, half-maximal effective concentration: 1050 nM
Beside the measured number, compound 3's estimate is 2.6-fold (0.42 log units) below it; the range from low to high includes it.
By their numbers in this assay, from the lowest: compound 1; then compounds 2 and 3 (each within the scatter of the next).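

In this assay, the exchange of benzyl for 1H-1,2,4-triazol-1-yl on this saturated chain carbon gives a 1.2-fold higher number from compound 2 to compound 3 (0.09 log units; within the scatter), so replacing a six-membered aromatic ring of carbon only with a five-membered aromatic ring with 3 hetero atoms makes no measurable difference here. The other new comparison, a 9.5-fold higher number from compound 1 to compound 3 (0.98 log units; beyond the scatter), adds a second aromatic ring that stands apart from pyrrolidin-1-yl, and compound 1 now holds the lowest number of the three, with its steps to both other compounds beyond the scatter; the earlier single step could not show that this gap was more than a feature of benzyl alone. No information on any property of these groups accompanies these numbers, so the comparison describes the result and offers no explanation of it.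

On these data alone, it remains open whether the lower number of compound 1 belongs to the pyrrolidin-1-yl ring specifically or would also appear with a piperidin-1-yl ring or an open-chain amine such as diethylamino. Also open, as far as these compounds go, is how any of these groups would behave on a shorter or longer chain.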